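A few compounds are considered here, and "the series" means these few. Any claim that something is new, unique, unknown or untested is made for them only; others in the source may bear on it.

Compound 1, `O=C([C@@H]1C[C@H]1c1ccccc1)N(CC1CCCNC1)c1ccc(-c2ccccc2)cc1`: 10 nM
Compound 2, `CCC(CC)C(N)CCN(C(=O)[C@@H]1C[C@H]1c1ccccc1)c1ccc(-c2ccccc2)cc1`: 2 nM
Compound 3, `CC(C)C[C@H](N)CN(C(=O)[C@@H]1C[C@H]1c1ccccc1)c1ccc(C2=CCCC2)cc1`: 1200 nM

Of the compounds shown here, three on a shared core have been measured in a functional assay for agonist activity at G protein-coupled receptor 88 (Homo sapiens), read by HTRF and cAMP accumulation; a lower number here means that less compound is needed, a higher number that more compound is needed for the effect. Compound 1 gives 10 nM. Compound 2 gives 2 nM, and the one measured step between two of these compounds, a 5.0-fold lower number from compound 1 to compound 2 (0.70 log units; beyond the scatter), lies on the chain carried by the amide-type nitrogen. Compound 3, which carries a cyclopent-1-en-1-yl group and yet another amine chain, gives 1200 nM and so stands highest of the three numbers, beyond the scatter from both compound 1 and compound 2.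

Compound 4, `CC(C)C[C@H](N)CN(C(=O)[C@@H]1C[C@H]1c1ccccc1)c1ccc(-c2cccc(F)c2)cc1`, differs from compound 3 in one place: 3-fluorophenyl in place of cyclopent-1-en-1-yl on an aromatic carbon. Among the measured compounds shown here, no measured step covers this change; the only measured step, from compound 1 to compound 2, concerns the amine chain and bears on it only indirectly. What the values do show is that compound 1 and compound 2, which carry a phenyl where compound 3 carries cyclopent-1-en-1-yl, both sit far below compound 3. Restoring an aromatic ring there is therefore expected to give a large downward step in this assay, though the chain of compound 3 differs from those of compound 1 and compound 2, so the size is uncertain. For compound 4 the estimated value is 30 nM, within 5 nM to 200 nM. The step this estimate means, a 40-fold lower number from compound 3 to compound 4 (1.60 log units; beyond the scatter), is an expectation only.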

Compound 4, half-maximal effective concentration: 2100 nM
For compound 4 the middle estimate is 70-fold (1.85 log units) below the measured one; measured number outside the range, above it.
By their numbers in this assay, from the lowest: compound 2; then compound 1; then compounds 3 and 4 (each within the scatter of the next).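

In this assay, exchanging cyclopent-1-en-1-yl for 3-fluorophenyl at this position, on an aromatic carbon para to a large group, gives a 1.8-fold higher number from compound 3 to compound 4 (0.24 log units; within the scatter), so on the amine chain of compound 3 the two groups cannot be told apart. The earlier compounds shown here differed from compound 3 in both the amine chain and this group and could not separate the two, whereas this pair shows that an aromatic ring with a fluorine, in place of the five-membered non-aromatic ring, leaves the number within the scatter on that chain. No available evidence explains this result, and the pair itself gives no cause for it.

The compounds shown leave open how the amine chain of compound 3 contributes on its own, since no pair here changes that chain alone, and whether compound 4 would read the same with an unsubstituted phenyl on this chain. They also leave open how this position responds to other groups on the outer ring, such as a methoxy group or a nitrile in place of the fluorine, or to an amine or a carboxylic acid there.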